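The source may hold more compounds than are shown below. What is called first, only, known or untested is meant among the compounds shown, and "the series" means these compounds.

Measured in a functional assay on HCT-116 cells (Homo sapiens) for cytotoxicity, read by MTT assay; a lower number here means a stronger inhibitor, a higher number a weaker inhibitor:
- compound 1 `Cc1cc(O)c(C(=O)/C=C/c2ccccc2F)c(=O)o1`: > 100000 nM (a limit)
- compound 2 `Cc1cc(O)c(C(=O)/C=C/c2ccc(F)cc2)c(=O)o1`: > 100000 nM (a limit)

Compound 2 gives > 100000 nM, which is a limit of the assay and not a number. Its standing is therefore (the limit of > 100000 nM in this assay, at which 2 of the 2 values shown sit). The next analogue is compound 3 `Cc1cc(O)c(C(=O)/C=C/c2ccc(F)cc2F)c(=O)o1`, which differs from compound 2 by fluoro in place of hydrogen on an aromatic carbon, ortho to a large group and meta to a fluoro group. Within the data shown here, no step between measured compounds is available to size this change. Compound 1 also gives only a limit, > 100000 nM. No shift beyond the scatter is expected in this assay, and most likely compound 3 will again be reported as a limit. The expected change is a number no higher from compound 2 to compound 3 (the limit leaves the size open). For compound 3 the estimated value is 100000 nM, with an expected range of 40000 nM to 250000 nM.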

Compound 3, half-maximal inhibitory concentration: 80300 nM
The estimate for compound 3 lay 1.2-fold (0.10 log units) above the measured number; the range from low to high includes it.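

In this assay, among these compounds, compound 3 gives 80300 nM, the only value shown that is a number and not a limit. Fluoro in place of hydrogen on the aromatic carbon ortho to a large group and meta to a fluoro group gives an at least 1.2-fold lower number from compound 2 to compound 3 (0.09 log units; that floor lies within the scatter), and the matching comparison with the other fluoro analogue gives an at least 1.2-fold lower number from compound 1 to compound 3 (0.09 log units; that floor lies within the scatter); neither floor establishes a shift beyond the scatter. The true size of each step stays open because both starting compounds sit at a limit: the limit of > 100000 nM in this assay, at which 2 of the 3 values shown sit.

On these data alone, whether a chloro, methoxy or amine group on this aromatic carbon would move the number beyond the scatter remains open. As far as these compounds go, the effect of a longer chain in place of the methyl group on the shared core is equally open.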